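From Acetyl to Methyl on the Aromatic Ring

The compounds below may be only part of what the source reports. "The series", "measured", "known", "first", "only" and "open" are said of these compounds alone.

Measured so far in a functional assay (aorta) with Rattus norvegicus as the target; a lower number here means a stronger inhibitor, a higher number a weaker inhibitor (compound 4 is still open)
- compound 1 (`CC1(C)Oc2ccc(C#N)cc2[C@@H](/N=C(\NC#N)Nc2ccccc2)[C@@H]1O`): 1400 nM; 1300 nM (2 entries)
- compound 2 (`CC1(C)Oc2ccc(C#N)cc2[C@@H](/N=C(\NC#N)NCc2ccccc2)[C@@H]1O`): 2400 nM
- compound 3 (`CC(=O)c1cccc(N/C(=N/[C@@H]2c3cc(C#N)ccc3OC(C)(C)[C@H]2O)NC#N)c1`): 8400 nM

Compound 3 (8400 nM) sits at the high end of these numbers. Within the data shown here, only one measured step connects two compounds that differ in a single place. Putting 3-acetylphenyl in place of benzyl on an amine nitrogen gives a 3.5-fold higher number from compound 2 to compound 3 (0.54 log units; beyond the scatter) (a modest step, but beyond the scatter).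

The next compound is compound 4 (`Cc1cccc(N/C(=N/[C@@H]2c3cc(C#N)ccc3OC(C)(C)[C@H]2O)NC#N)c1`). It has methyl in place of acetyl on an aromatic carbon, turning 3-acetylphenyl into 3-methylphenyl (methyl in place of acetyl on an aromatic carbon). Among the measured compounds shown here, no measured step isolates this exact change, so the evidence is indirect. Compound 1 has an aromatic ring without the acetyl group and reads 1400 nM; 1300 nM (2 entries) in this assay. For the measured compounds named here, that number is lower than the one for compound 3, and compound 2 also reads lower. Going by the values given here, with only three compounds, this is a hint and not a rule. Losing the acetyl group is therefore expected to bring the number down, by about the size of the measured step but in the opposite direction. The expected change is a 3.8-fold lower number from compound 3 to compound 4 (0.58 log units; beyond the scatter) (a drop toward the values of compound 1). For compound 4 the estimated value is 2200 nM (expected range 800 nM to 6000 nM).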

Compound 4, half-maximal inhibitory concentration: 1000 nM
Beside the measured number, compound 4's estimate is 2.2-fold (0.34 log units) above it, within the range that was stated.
By their numbers in this assay, from the lowest: compound 4; then compound 2; then compound 3.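

In this assay, this aromatic carbon now has a direct comparison in which only the group changes: acetyl gives way to methyl, and the result is an 8.4-fold lower number from compound 3 to compound 4 (0.92 log units; beyond the scatter). The 3-methylphenyl group also compares well with benzyl, with a 2.4-fold lower number from compound 2 to compound 4 (0.38 log units; beyond the scatter), whereas 3-acetylphenyl went the opposite way against benzyl, so the higher number of compound 3 belongs to acetyl and not to every group at this place. A group here can therefore be present without raising the number, since compound 4 gives a value close to that of compound 1, which carries nothing at this place and whose repeated readings agree closely: the several entries of compound 1 in this assay, 1400 nM; 1300 nM (2 entries).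

Only acetyl and methyl can be compared at this aromatic carbon, so the compounds shown cannot separate the effect of the size of the group from that of its carbonyl. An ethyl group, a methoxy group, an amine or a carboxylic acid on the same carbon would show which of these differences tracks the number, and whether anything at this place can bring it clearly lower than in compound 1.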